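The compounds below may be only part of what the source reports. "The series", "measured", "known", "first", "only" and "open" are said of these compounds alone.

Compound 1 `Cc1nn2ccc(Cl)cc2c1C(=O)NCc1ccc(N2CCC(c3ccc(OC(F)(F)F)cc3)CC2)cc1`: in an ADME assay on Vero cells (Chlorocebus sabaeus) for cytotoxicity, read by CCK-8 assay, with a stated time of 72 h (a lower number here means a stronger inhibitor, a higher number a weaker inhibitor), compound 1 gives > 100000 nM, which is a limit of the assay rather than a number.
Compound 2 `O=C(NCc1ccc(N2CCC(c3ccc(OC(F)(F)F)cc3)CC2)cc1)c1cnn2ccc(Cl)cc12`: in this assay compound 2 gives "not determined" (no result reported).
Compound 3 `CCc1nn2ccc(Cl)cc2c1C(=O)NCc1ccc(N2CCC(c3ccc(OC(F)(F)F)cc3)CC2)cc1`: in this assay compound 3 gives > 100000 nM, again a limit and not a number.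

Compound 3 therefore stands at a limit in this assay, with no single number of its own. Of the three entries shown, two sit at that same limit and one carries no result. Among the compounds with values here, the only step that can be drawn, a step that the two limits leave unreadable from compound 1 to compound 3, joins two limits and its size cannot be read.

The change to compound 4 `O=C(NCc1ccc(N2CCC(c3ccc(OC(F)(F)F)cc3)CC2)cc1)c1c(C2CC2)nn2ccc(Cl)cc12` is cyclopropyl in place of ethyl on an aromatic carbon. Within the data shown here, the one measured step, a methyl for a hydrogen on the same core, bears on this change only loosely, and because the limit of > 100000 nM in this assay, at which 2 of the 3 values shown sit, holds both neighbouring compounds, no movement beyond the scatter is expected in this assay. Compound 4 is expected to give 150000 nM, between 50000 nM and 500000 nM. The expected step is a step that the limit leaves unreadable from compound 3 to compound 4, essentially none.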

Compound 4, half-maximal inhibitory concentration: > 100000 nM
Compound 4 gave a limit, no number; the forecaster's own chance of this, stated with the estimate: 85%; the middle value lies beyond the limit too.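

No step can be read between compound 4 and either compound 1 or compound 3 in this assay: all three give limits, not numbers. Whether the methyl, ethyl and cyclopropyl groups differ at all in this assay stays open, with no single number among the compounds shown.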